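Indolyl to dichloroanilino swap on the shared core

The compounds below may be only part of what the source reports. "The series", "measured", "known", "first", "only" and "open" are said of these compounds alone.

Measured so far in a functional assay on HCT-116 cells (Homo sapiens) for inhibition, with a stated time of 72 h (a lower number here means a stronger inhibitor of growth, a higher number a weaker inhibitor of growth), for this series
- compound 1 `O=C(c1cc(-n2ccc3ccccc32)c(O)cc1O)N1Cc2ccccc2C1` gives 10100 nM
- compound 2 `Cc1ccc2c(ccn2-c2cc(C(=O)N3Cc4ccccc4C3)c(O)cc2O)c1` gives 8600 nM

Going by the values given here, compound 1 stands level with compound 2, the only other measured compound, since the two lie within the scatter of each other. Compound 3 `O=C(c1cc(Nc2ccc(Cl)cc2Cl)c(O)cc1O)N1Cc2ccccc2C1` keeps the core of compound 1 and carries (2,4-dichlorophenyl)amino in place of 1H-indol-1-yl on an aromatic carbon, ortho to a hydroxy group and para to a hydroxy group ((2,4-dichlorophenyl)amino in place of 1H-indol-1-yl on an aromatic carbon).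

Among the compounds with values here, only one measured step bears on this change, and only loosely. The step of a 1.2-fold lower number from compound 1 to compound 2 (0.07 log units; within the scatter) comes from methyl in place of hydrogen on an aromatic carbon, inside the group that leaves here. Within the data shown here, no measured compound carries the entering group, so the data give no direction, and no step beyond the scatter is expected in this assay, with wide uncertainty on either side. The estimate amounts to an expected 1.3-fold lower number from compound 1 to compound 3 (0.10 log units; within the scatter) in this series. For compound 3 the expected value is 8000 nM (estimated range 2000 nM to 30000 nM).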

Compound 3, concentration for 50% growth inhibition: 10600 nM
Estimate against measurement, compound 3: 1.3-fold (0.12 log units) below; the range from low to high includes it.
By their numbers in this assay, from the lowest: compounds 2, 1 and 3 (each within the scatter of the next).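

In this assay, replacing the whole of 1H-indol-1-yl with (2,4-dichlorophenyl)amino gives a 1.0-fold higher number from compound 1 to compound 3 (0.02 log units; within the scatter), so this larger change stays within the scatter, as does the smaller methyl change inside the indolyl group, a 1.2-fold lower number from compound 1 to compound 2 (0.07 log units; within the scatter). This position, on an aromatic carbon ortho to a hydroxy group and para to a hydroxy group, therefore carries either group without a step beyond the scatter, even though the entering group has one six-membered aromatic ring of carbon only and 1 hydrogen-bond donor, while the leaving group has a five-membered aromatic ring as well and 0 hydrogen-bond donors. No supporting measurement is available to account for this flat result.

Still open, from the compounds shown here alone, is whether any group on this aromatic carbon can move the number beyond the scatter, for instance a piperidin-1-yl amine, a carboxylic acid or a longer alkyl chain. Also open, going by these compounds, is how methoxy in place of either hydroxy group on the shared core would read in this assay when (2,4-dichlorophenyl)amino is kept.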